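The source may report more compounds than this note shows. Statements on the series, on what has been measured and on what is new or still open speak of the compounds shown alone.

Measured in a functional assay on A549 cells (Homo sapiens) for inhibition, read by MTT assay, with a stated time of 72 h; on this read-out lower numbers stand for stronger inhibition and higher numbers for weaker inhibition:
- compound 1 `CC(C)c1ccc(NC(=O)C2CCN(C/C=C/c3ccccc3)CC2)cc1`: 9430 nM
- compound 2 `COc1ccc(NC(=O)C2CCN(C/C=C/c3ccccc3)CC2)cc1`: 83800 nM
- compound 3 `O=C(Nc1cccc(Cl)c1)C1CCN(C/C=C/c2ccccc2)CC1`: 19100 nM

Compound 3 (19100 nM) holds the second highest number of the three, lying between compound 1 and compound 2. Next is compound 4 `N#Cc1ccc(NC(=O)C2CCN(C/C=C/c3ccccc3)CC2)cc1`, with 4-cyanophenyl in place of 3-chlorophenyl on an amide-type nitrogen.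

Going by the values given here, three measured steps bear on this change, all modest. Two change the group on the same nitrogen and run in opposite directions (a 2.0-fold higher number from compound 1 to compound 3 (0.31 log units; beyond the scatter)) (a 4.4-fold lower number from compound 2 to compound 3 (0.64 log units; beyond the scatter)). The third shows the spread between the other two groups (an 8.9-fold higher number from compound 1 to compound 2 (0.95 log units; beyond the scatter)). Among the compounds with values here, no measured compound carries the 4-cyanophenyl group, so the direction is poorly defined. A value within the band set by compound 1 and compound 2 is expected, which suggests a small move towards a higher number (a 1.5-fold higher number from compound 3 to compound 4 (0.17 log units; within the scatter)). The estimated value for compound 4 is (28000 nM), with an expected range of (10000 nM to 80000 nM).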

Compound 4, half-maximal inhibitory concentration: 40200 nM
Compound 4: the middle estimate sits 1.4-fold (0.16 log units) below what was measured, within the range that was stated.
By their numbers in this assay, from the lowest: compound 1; then compound 3; then compound 4; then compound 2.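

In this assay, 4-cyanophenyl on the amide-type nitrogen reads weaker than 3-chlorophenyl (a 2.1-fold higher number from compound 3 to compound 4 (0.32 log units; beyond the scatter)) and weaker than the isopropyl-bearing compound (a 4.3-fold higher number from compound 1 to compound 4 (0.63 log units; beyond the scatter)), yet stronger than the methoxy-bearing compound (a 2.1-fold lower number from compound 2 to compound 4 (0.32 log units; beyond the scatter)). With all three steps beyond the scatter, the four compounds form a clear order at this position, and the nitrile keeps compound 4 inside the band set by compound 1 and compound 2 rather than extending it in either direction. No measured evidence accounts for this order.

Chloro and cyano appear only as 3-chlorophenyl and 4-cyanophenyl, so the step from compound 3 mixes a change of group with a change of where it sits on the ring. On these data alone, how a primary amine or a carboxylic acid on the aromatic carbon would fit into this order remains open.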